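The source may hold more compounds than are shown below. What is called first, only, known or untested is meant among the compounds shown, and "the series" means these compounds.

Values in a functional assay on RAW264.7 cells (Mus musculus) for inhibition, with stated times of 2 h and 24 h; on this read-out higher numbers stand for weaker inhibition and lower numbers for stronger inhibition:
- compound 1 `COc1cc(OC)cc([C@@H]2C(O)c3cc(OC)cc(OC)c3[C@H]2c2ccccc2)c1`: 3380 nM
- compound 2 `COc1ccc(CSC2c3cc(OC)cc(OC)c3[C@@H](c3ccccc3)[C@@H]2c2cc(OC)cc(OC)c2)cc1`: > 200000 nM
- compound 3 `COc1cc(OC)cc([C@@H]2C(C(O)c3ccccc3)c3cc(OC)cc(OC)c3[C@H]2c2ccccc2)c1`: not yet measured

Compound 2 gives only a limit of the assay, > 200000 nM, and not a number. The next change is hydroxy(phenyl)methyl in place of (4-methoxybenzyl)sulfanyl on a saturated ring carbon. For the measured compounds named here, one measured step bears on it, the large at least 59-fold higher number from compound 1 to compound 2 (1.77 log units; beyond the scatter), which came with the arrival of (4-methoxybenzyl)sulfanyl in place of hydroxy. With that group gone, a large step towards stronger inhibition is expected in this assay. The expected change is an at least 16-fold lower number from compound 2 to compound 3 (1.22 log units; beyond the scatter). Compound 3 is estimated at 12000 nM, with an expected range of 2500 nM to 60000 nM.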

Compound 3, half-maximal inhibitory concentration: 21600 nM
For compound 3 the middle estimate is 1.8-fold (0.26 log units) below the measured one; low and high end bracket the measured number.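

At this saturated ring carbon, hydroxy(phenyl)methyl in place of (4-methoxybenzyl)sulfanyl recovers measurable inhibition in this assay, with an at least 9.2-fold lower number from compound 2 to compound 3 (0.96 log units; beyond the scatter) as the step. The value of compound 2 is a limit and not a number: the limit of > 200000 nM in this assay, at which 1 of the 3 values shown sits. Hydroxy(phenyl)methyl in place of hydroxy still gives a 6.4-fold higher number from compound 1 to compound 3 (0.81 log units; beyond the scatter) on the same read-out, so the simple hydroxy remains the better of these two groups.

Open, from the compounds shown here alone, is whether the hydroxy of hydroxy(phenyl)methyl matters, which a benzyl group would test. Also open, going by these compounds, is how an amine or a carboxylic acid at this carbon would compare.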